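Cytotoxicity notes: furan-3-yl swapped for an open-chain group

This account rests on a few compounds, and the source may have more. Where it says the series, first, only, none or still open, it means among the compounds named here.

The compounds share one core and differ only in the group on an aromatic carbon. Compound 1 `CS/C=C/c1nn(C2C[C@@H](O)[C@@H](CO)O2)c(=O)[nH]c1=O` gives 420 ug/mL in a functional assay on Vero cells (Chlorocebus sabaeus) for cytotoxicity; on this read-out higher numbers stand for weaker inhibition and lower numbers for stronger inhibition. Compound 2 `O=c1[nH]c(=O)n(C2C[C@@H](O)[C@@H](CO)O2)nc1C=C(Br)Br` gives only > 500 ug/mL in this assay, which is the limit of > 500 ug/mL in this assay, at which 1 of the 3 values shown sits, and not a number. Going by the values given here, compound 3 `O=c1[nH]c(=O)n(C2C[C@@H](O)[C@@H](CO)O2)nc1-c1ccoc1` gives 45 ug/mL in this assay, the lowest of the two numbers known, and so compound 3 is the strongest inhibitor among the measured compounds. The steps into compound 3 are a 9.3-fold lower number from compound 1 to compound 3 (0.97 log units; beyond the scatter) and an at least 11-fold lower number from compound 2 to compound 3 (1.04 log units; beyond the scatter); both put furan-3-yl in place of a group with no ring and both lowered the number beyond the scatter. The two compounds without a ring differ by an at least 1.1-fold higher number from compound 1 to compound 2 (0.07 log units; that floor lies within the scatter), within the scatter.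

Compound 4 `COC(F)(F)Cc1nn(C2C[C@@H](O)[C@@H](CO)O2)c(=O)[nH]c1=O` differs from compound 3 by a group of 6 heavy atoms (3 carbon, 1 oxygen, 2 fluorine; no ring) in place of a group of 5 heavy atoms (4 carbon, 1 oxygen; one five-membered aromatic ring with 1 hetero atom), on an aromatic carbon The change runs opposite to the two steps that brought furan-3-yl in: a ring leaves and a group without a ring enters. Among the compounds with values here, a step upward in this assay is therefore expected, roughly undoing those two steps, though the entering group has no precedent in the set and the size is uncertain. The expected step is a 7.3-fold higher number from compound 3 to compound 4 (0.87 log units; beyond the scatter). Compound 4 is expected to give 330 ug/mL in this assay, within a range from 110 ug/mL to 500 ug/mL.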

Compound 4, concentration for 50% inhibition: > 500 ug/mL
Compound 4: a limit, no number (the forecaster's own chance of this, stated with the estimate: 30%); at least 1.5-fold (0.18 log units) between middle value and limit.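

In this assay compound 4 is a limit of the assay and not a number: the limit of > 500 ug/mL in this assay, at which 2 of the 4 values shown sit.

The fluorine-bearing group of 6 heavy atoms gives an at least 11-fold higher number from compound 3 to compound 4 (1.04 log units; beyond the scatter), so on this aromatic carbon a third group with no ring now lies on the high side of furan-3-yl, and in the compounds shown no compound goes against that split. The step of an at least 1.1-fold higher number from compound 1 to compound 4 (0.07 log units; that floor lies within the scatter) has a floor within the scatter and gives no order among the groups with no ring, and the step between the two limits cannot be read.

With furan-3-yl as the only ring shown, the compounds leave open whether the lower number goes with rings at this position in general or with this one group. A phenyl ring, a saturated cyclopentyl ring or a carboxylic acid on the same aromatic carbon would help separate those two readings.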